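Swapping the para group of a sulfonyl piperidine ester

A few compounds are considered here, and "the series" means these few. Any claim that something is new, unique, unknown or untested is made for them only; others in the source may bear on it.

Compound 1 `CCOC(=O)[C@@H]1CCCN(S(=O)(=O)c2ccc(S(=N)(=O)N(CC)CC)cc2)C1`: 2600 nM
Compound 2 `CCOC(=O)[C@@H]1CCCN(S(=O)(=O)c2ccc(S(=O)(=O)N(C)Cc3ccccc3)cc2)C1`: > 30000 nM (a limit of the assay, not a number)
Compound 3 `CCOC(=O)[C@@H]1CCCN(S(=O)(=O)c2ccc(C(=O)N(CC)CC)cc2)C1`: 800 nM

All three share one core and differ only in the group on the far aromatic carbon. In a functional assay on MIA PaCa-2 cells (Homo sapiens) for inhibition, read by MTT assay, with a stated time of 7 days (a lower number here means a stronger inhibitor, a higher number a weaker inhibitor), compound 3 gives 800 nM, the lowest number of the two numbers that were obtained. Compound 1 sits a 3.3-fold lower number from compound 1 to compound 3 (0.51 log units; beyond the scatter) away; that is, the carbonyl-bearing group of compound 3 gives the lower number. For compound 2 the result is only a limit, > 30000 nM, so it cannot be placed against the others (the limit of > 30000 nM in this assay, at which 1 of the 3 values shown sits).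

Compound 4 `CCOC(=O)[C@@H]1CCCN(S(=O)(=O)c2ccc(S(=O)(=O)N(C)C)cc2)C1` has not yet been measured. It differs from compound 3 as follows: dimethylsulfamoyl in place of diethylcarbamoyl on an aromatic carbon. Within the data shown here, the one measured step that bears on this change runs the other way, from a sulfur-bearing group toward a carbonyl, and gave a modest gain; here a sulfur-bearing group replaces the carbonyl, so a modest rise in the number is expected, roughly a 5.0-fold higher number from compound 3 to compound 4 (0.70 log units; beyond the scatter). Compound 4 is therefore estimated at 4000 nM in this assay, with a range from 1200 nM to 20000 nM.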

Compound 4, half-maximal inhibitory concentration: 900 nM
Compound 4: middle estimate off by 4.4-fold (0.65 log units), on the high side, and the stated range ends above it.
By their numbers in this assay, from the lowest: compounds 3 and 4 (each within the scatter of the next); then compound 1. At a limit, above all of these: compound 2.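

In this assay, the change from diethylcarbamoyl to dimethylsulfamoyl gives a 1.1-fold higher number from compound 3 to compound 4 (0.05 log units; within the scatter), so on this aromatic carbon the two groups cannot be told apart, and a sulfur-bearing group here does not by itself bring a higher number. The sulfur-bearing group of the core's other measured neighbour is not equivalent, however, as the swap to dimethylsulfamoyl gives a 2.9-fold lower number from compound 1 to compound 4 (0.46 log units; beyond the scatter), which shows that the whole group matters and not only the atom attached to the carbon chain of thought that began with the carbonyl. The one result that is a limit, and not a number, gives an at least 33-fold lower number from compound 2 to compound 4 (1.52 log units; beyond the scatter), with hydrogen in place of phenyl on a saturated chain carbon bound to a sulfonamide nitrogen as the only difference: the limit of > 30000 nM in this assay, at which 1 of the 4 values shown sits.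

The compounds shown leave open whether the match between the sulfamoyl and carbamoyl groups would hold with equal substituents on the nitrogen, for instance in a diethylsulfamoyl or a dimethylcarbamoyl group. They also leave open how a longer chain on that nitrogen, or an amine at the end of such a chain, would compare with the small groups and with phenyl.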